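This account rests on a few compounds, and the source may have more. Where it says the series, first, only, none or still open, it means among the compounds named here.

Three compounds have been measured in an in vitro functional assay on HEK285-7 cells for antagonist activity at prostaglandin D2 receptor 2 (Homo sapiens), read by BRET and beta-arrestin recruitment; a lower number here means a smaller maximal response, a higher number a larger maximal response:

compound 1, `O=C(O)Cc1sc(C(c2ccccc2)c2ccccc2)nc1-c1ccc(C(F)(F)F)cc1`: 80%
compound 2, `COc1cc(-c2nc(C(c3ccc(F)cc3)c3ccc(F)cc3)sc2CC(=O)O)ccn1`: 60%
compound 3, `O=C(O)Cc1sc(C(c2ccccc2)c2ccc(Cl)cc2)nc1-c1ccc(Cl)cc1`: 80%

Compound 1 stands level with compound 3 at the digits shown, the two sharing the top of the three numbers, and the difference between them lies within the usual scatter of this assay . Compound 2, by contrast, returns a maximal response that is lower than that of compound 1 by a margin beyond the scatter, so compound 1 is clearly separated from compound 2 but not from compound 3.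

The next compound, compound 4 `O=C(O)Cc1sc(C(c2ccccc2)c2ccccc2)nc1-c1cccc(F)c1`, differs from compound 1 in a single place: 3-fluorophenyl in place of 4-(trifluoromethyl)phenyl on an aromatic carbon. Among the compounds with values here, no step between measured compounds covers this kind of change, so the expectation rests only on the values of compound 1 and compound 3, which hold the same maximal response with different substituted phenyl groups on the shared core. Compound 4 is therefore expected to give 75%, with a range from 55% to 95%. This estimate means a step of a number 5 percentage points lower from compound 1 to compound 4 (within the scatter), expected to stay within the scatter or to lean only slightly downward.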

Compound 4, largest response reached (reported as efficacy), in percent of the reference or control that the assay uses: 80%
Compound 4: middle estimate off by 5 percentage points, on the low side, and the stated range covers the measured number.
By their numbers in this assay, from the lowest: compound 2; then compounds 1, 3 and 4 (each within the scatter of the next).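

Read in this assay, putting 3-fluorophenyl in place of 4-(trifluoromethyl)phenyl on the aromatic carbon next to the ring nitrogen gives no change at the digits printed from compound 1 to compound 4 (within the scatter), the only single-place comparison shown so far. The maximal response at this position therefore holds when the group goes from 10 heavy atoms to 7 and trifluoromethyl gives way to a single fluorine, although this one step changes both the substituent and where it sits on the phenyl ring, so the two changes cannot be told apart. Nothing measured here offers an explanation for this outcome.

From the compounds shown here alone, it remains open whether an unsubstituted phenyl, a nitrile-bearing phenyl or an amine at this position would keep the response. Going by these compounds, the effect of replacing the carboxymethyl group with a longer carboxylic acid chain is also open.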